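A few compounds are considered here, and "the series" means these few. Any claim that something is new, unique, unknown or untested is made for them only; others in the source may bear on it.

Compound 1 `Cc1nsc(-c2ccc(N3CCN(c4cccc(F)c4)CC3)nn2)n1` gives 6 nM in a functional assay (aorta) for inhibition, with Rattus norvegicus as the target, with a stated time of 8 days; a higher number here means a weaker inhibitor, a lower number a stronger inhibitor
Compound 2 `Cc1nsc(-c2ccc(N3CCN(c4cccc([N+](=O)[O-])c4)CC3)nn2)n1` gives 3 nM
Compound 3 `COc1cccc(N2CCN(c3ccc(-c4nc(C)ns4)nn3)CC2)c1` gives 7 nM

For compound 3 the data show a 1.2-fold higher number from compound 1 to compound 3 (0.07 log units; within the scatter) and also a 2.3-fold higher number from compound 2 to compound 3 (0.37 log units; beyond the scatter), so it matches compound 1 and sits only modestly apart from compound 2. The change under review leads to compound 4 `Cc1nsc(-c2ccc(N3CCN(c4cc(Cl)cc(Cl)c4)CC3)nn2)n1`, with 3,5-dichlorophenyl in place of 3-methoxyphenyl on an amine nitrogen in a ring. The measured swaps on an aromatic carbon bear on this, and they stayed small, with a 2.0-fold lower number from compound 1 to compound 2 (0.30 log units; within the scatter) as well. Going by the values given here, no measured compound carries chlorine, so the read-across is loose. In this assay no step beyond the scatter is expected, the estimate being a 1.2-fold lower number from compound 3 to compound 4 (0.07 log units; within the scatter). For compound 4 the estimated value is 6 nM, with an expected range from 2 nM to 18 nM.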

Compound 4, half-maximal inhibitory concentration: < 0.1 nM
Compound 4 gave a limit, no number; the forecaster's own chance of this, stated with the estimate: 3%; at least 60-fold (1.77 log units) between middle value and limit.
By their numbers in this assay, from the lowest: compounds 2, 1 and 3 (each within the scatter of the next, the first and the last beyond it). At a limit, below all of these: compound 4.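

On the aryl group on the amine nitrogen of the six-membered ring, swaps among compounds 1, 2 and 3 stayed small to modest, whereas 3,5-dichlorophenyl brings a large change: an at least 70-fold lower number from compound 3 to compound 4 (1.84 log units; beyond the scatter) and an at least 60-fold lower number from compound 1 to compound 4 (1.77 log units; beyond the scatter) and also an at least 30-fold lower number from compound 2 to compound 4 (1.47 log units; beyond the scatter). In this assay compound 4 gives a limit, not a number, so the full size of these steps stays unread: the limit of < 0.1 nM in this assay, at which 1 of the 4 values shown sits.

The compounds shown leave open whether 3-chlorophenyl alone would give the same gain, and whether 3,5-dibromophenyl or 3,5-dimethylphenyl would follow it.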